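Chloro for methoxy on compound 3's aromatic ring

The source may hold more compounds than are shown below. What is called first, only, known or untested is meant among the compounds shown, and "the series" means these compounds.

Compound 1 `COc1ccc(NS(=O)(=O)c2ccc(-c3ccccn3)s2)cc1N1C[C@@H](C)N[C@@H](C)C1` gives 0.9 in a functional assay for agonist activity at growth hormone secretagogue receptor type 1 (Homo sapiens), read by FLIPR; on this read-out lower numbers stand for smaller maximal responses and higher numbers for larger maximal responses. Compound 2 `C[C@@H]1CN(c2cc(NS(=O)(=O)c3ccc(-c4ccccn4)s3)ccc2C#N)C[C@H](C)N1` gives 0.9. The step of no change at the digits printed from compound 1 to compound 2 (within the scatter), a cyano in place of methoxy on an aromatic carbon, is therefore flat. Compound 3 `COc1ccc(N2C[C@@H](C)N[C@@H](C)C2)cc1NS(=O)(=O)c1ccc(-c2ccccn2)s1` gives 1.1, the highest of the three values, beyond the scatter from both compound 1 and compound 2. Compound 4 `C[C@@H]1CN(c2ccc(Cl)c(NS(=O)(=O)c3ccc(-c4ccccn4)s3)c2)C[C@H](C)N1` differs from compound 3 in one place: chloro in place of methoxy on an aromatic carbon. Among the measured compounds shown here, the only measured step on this scaffold, the flat one from compound 1 to compound 2, replaces a methoxy group as well and bears on this change. The expected step is therefore a number 0.10 lower from compound 3 to compound 4 (within the scatter). Compound 4 is estimated at 1, between 0.85 and 1.15.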

Compound 4, intrinsic activity: the largest response reached, as a fraction of the reference agonist's: 1
The estimate for compound 4 equals the measured number at the digits printed; the measured number falls inside the stated range.
By their numbers in this assay, from the lowest: compounds 1, 2, 4 and 3 (each within the scatter of the next, the first and the last beyond it).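

In this assay the change from methoxy to chloro, para to a 3,5-dimethylpiperazin-1-yl group, is a number 0.10 lower from compound 3 to compound 4 (within the scatter) and so reaches a place that the earlier step on compound 1 did not touch. Here the maximal response holds with a single chlorine atom in place of the methoxy group and its hydrogen-bond acceptor. Nothing at hand explains this. Still open, on these data alone, is whether an amine, a hydroxyl group or a longer chain such as ethoxy on this aromatic carbon would hold the response too.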